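Methyl on a saturated ring carbon: cytotoxicity notes

The compounds below may be only part of what the source reports. "The series", "measured", "known", "first", "only" and "open" are said of these compounds alone.

Compound 1 `O=c1cc(N2CCN(c3nccs3)CC2)sc2c([N+](=O)[O-])cc(C(F)(F)F)cc12` and compound 2 `O=c1cc(N2CCN(CC3CCCCC3)CC2)sc2c([N+](=O)[O-])cc(C(F)(F)F)cc12` share one core. In an ADME assay on Vero cells (Chlorocebus sabaeus) for cytotoxicity, read by MTT assay, with a stated time of 48 h (on this read-out lower numbers stand for stronger inhibition and higher numbers for weaker inhibition), compound 1 gives only a limit, > 64 ug/mL. In this assay compound 2 also gives only a limit, > 64 ug/mL. Both sit at the same limit (the limit of > 64 ug/mL in this assay, at which 2 of the 2 values shown sit), so the step that the two limits leave unreadable from compound 1 to compound 2 cannot be read. Compound 3 `CC1CN(c2cc(=O)c3cc(C(F)(F)F)cc([N+](=O)[O-])c3s2)CCN1CC1CCCCC1` differs from compound 2 by methyl in place of hydrogen on a saturated ring carbon. No measured step in this assay bears on this change; the single step shown is unreadable. For compound 3 the expected step is a step that the limit leaves unreadable from compound 2 to compound 3, nothing beyond the scatter. Compound 3 is estimated at 90 ug/mL, within 40 ug/mL to 200 ug/mL, and is expected to be reported again only as a limit.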

Compound 3, half-maximal inhibitory concentration: > 64 ug/mL
Compound 3: a limit, no number; the forecaster's own chance of this, stated with the estimate: 85%; the middle value does not contradict the limit.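

For the compounds shown here, compound 2 and compound 3 are both limits and no number in this assay, so no step between them can be read: the limit of > 64 ug/mL in this assay, at which 3 of the 3 values shown sit. The compounds shown leave open whether methyl in place of hydrogen on a saturated ring carbon changes cytotoxicity at all.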